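The source may report more compounds than this note shows. Statements on the series, on what has been measured and on what is new or still open speak of the compounds shown alone.

Of the compounds shown here, three that share one core have been measured in a functional assay on CRL2813 cells (Homo sapiens) for cytotoxicity, read by sulforhodamine B assay, with a stated time of 5 days; on this read-out lower numbers stand for stronger inhibition and higher numbers for weaker inhibition. Compound 1 `COC(=O)c1ccc(NC(=O)N[C@H]2CC[C@H](Oc3ccc(F)cc3)CC2)cc1` gives 11600 nM. Compound 2 `O=C(Nc1cccc(Cl)c1)N[C@H]1CC[C@H](Oc2ccc(F)cc2)CC1` gives 5900 nM. Compound 3 `O=C(Nc1ccc(I)cc1)N[C@H]1CC[C@H](Oc2ccc(F)cc2)CC1` gives 10200 nM, which places compound 3 second highest of the three numbers, nearest to compound 1 and furthest from compound 2; both gaps lie within the scatter, so no real ordering can be read from them.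

The new compound 4 `O=C(Nc1ccccc1Cl)N[C@H]1CC[C@H](Oc2ccc(F)cc2)CC1` differs from compound 3 in one place: 2-chlorophenyl in place of 4-iodophenyl on an amide-type nitrogen. One measured step compares a 3-chlorophenyl with a 4-iodophenyl on the same amide-type nitrogen: a 1.7-fold higher number from compound 2 to compound 3 (0.24 log units; within the scatter). The other step, a 1.1-fold lower number from compound 1 to compound 3 (0.06 log units; within the scatter), changes the group on an aromatic carbon instead and bears less directly on the present change. Among the compounds with values here, neither step goes beyond the scatter, and no pair differing only between 3-chlorophenyl and 2-chlorophenyl has been measured, so the data offer no ground for a large shift.

The step to compound 4 is therefore expected to be small and in no firm direction: a 1.3-fold lower number from compound 3 to compound 4 (0.11 log units; within the scatter). Compound 4 is estimated at 8000 nM, with a range from 3000 nM to 20000 nM.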

Compound 4, half-maximal inhibitory concentration: 9100 nM
Beside the measured number, compound 4's estimate is 1.1-fold (0.06 log units) below it; measured number inside the range.
By their numbers in this assay, from the lowest: compounds 2, 4, 3 and 1 (each within the scatter of the next).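

In this assay, 2-chlorophenyl on the amide-type nitrogen gives a 1.1-fold lower number from compound 3 to compound 4 (0.05 log units; within the scatter) when it replaces 4-iodophenyl, and a 1.5-fold higher number from compound 2 to compound 4 (0.19 log units; within the scatter) when it replaces 3-chlorophenyl. Within the data shown here, the second step is the new information: it is the first pair in which the aryl group keeps its chlorine and only the chlorine's place on the ring differs, and that difference cannot be told from the ordinary spread of repeat measurements. So at this nitrogen, the four aryl groups shown, which carry chlorine, iodine or methoxycarbonyl, give numbers that cannot be separated, and no measurement here offers an explanation for that.

On these data alone, what remains open is whether any group at this nitrogen can move the number beyond the scatter, for example a phenyl ring carrying an amine or a carboxylic acid, or a longer alkyl chain in place of the aryl ring. Also open, as far as these compounds go, is whether changes elsewhere in the shared core would matter more than those at this nitrogen, since all four compounds keep the rest of that core the same.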